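This account rests on a few compounds, and the source may have more. Where it says the series, first, only, none or still open, it means among the compounds named here.

Measured compounds in a functional assay on MGC-803 cells (Homo sapiens) for inhibition, read by sulforhodamine B assay; on this read-out lower numbers stand for stronger inhibition and higher numbers for weaker inhibition:
compound 1 `CCCc1ccc(NC2=CC(=O)c3nc4n(c3C2=O)[C@H]2OC[C@@H](O)[C@H]2OC4)cc1` gives 1560 nM;
compound 2 `COc1ccc(NC2=CC(=O)c3nc4n(c3C2=O)[C@H]2OC[C@@H](O)[C@H]2OC4)cc1` gives 1680 nM;
compound 3 `CCCN(CCC)C1=CC(=O)c2nc3n(c2C1=O)[C@H]1OC[C@@H](O)[C@H]1OC3` gives > 16000 nM.

The value of compound 3 in this assay is a limit of the assay, not a number, as the limit of > 16000 nM in this assay, at which 1 of the 3 values shown sits, shows. Compound 3 therefore stands at the weak end of the three values shown, with its step from compound 2 recorded as an at least 9.5-fold higher number from compound 2 to compound 3 (0.97 log units; beyond the scatter).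

Compound 4 `O=C1C=C(Nc2cccc(F)c2)C(=O)c2c1nc1n2[C@H]2OC[C@@H](O)[C@H]2OC1` is not yet measured in this assay. Its change from compound 3 is (3-fluorophenyl)amino in place of dipropylamino on a double-bonded ring carbon. This step runs the other way to the measured step of an at least 9.5-fold higher number from compound 2 to compound 3 (0.97 log units; beyond the scatter), in which an aryl amino group gave way to dipropylamino and the number rose well beyond the scatter. The step of a 1.1-fold higher number from compound 1 to compound 2 (0.03 log units; within the scatter) shows that exchanging one aromatic substituent for another left the number within the scatter, so the fluorine on the ring is expected to matter little.

Compound 4 is therefore expected to fall back toward the values of compound 1 and compound 2, a step of an at least 9.4-fold lower number from compound 3 to compound 4 (0.97 log units; beyond the scatter) in this assay, giving an estimated 1700 nM with a range from 700 nM to 4500 nM.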

Compound 4, half-maximal inhibitory concentration: 2180 nM
For compound 4 the middle estimate is 1.3-fold (0.11 log units) below the measured one; the measured number falls inside the stated range.
By their numbers in this assay, from the lowest: compounds 1, 2 and 4 (each within the scatter of the next). At a limit, above all of these: compound 3.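

In this assay, putting an aryl amino group back on the double-bonded ring carbon gives an at least 7.3-fold lower number from compound 3 to compound 4 (0.86 log units; beyond the scatter), which again brings the number close to those of compounds 1 and 2, so this position responds in both directions to the change between dipropylamino and an aryl amino group. The group on the phenyl ring matters little among these compounds, with 3-fluorophenyl reading alike to 4-methoxyphenyl, a 1.3-fold higher number from compound 2 to compound 4 (0.11 log units; within the scatter), and to 4-propylphenyl, a 1.4-fold higher number from compound 1 to compound 4 (0.15 log units; within the scatter). The value of compound 3 is a limit of the assay and not a number: the limit of > 16000 nM in this assay, at which 1 of the 4 values shown sits.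

The compounds shown leave open whether the aromatic ring or the amine hydrogen counts here, since the two enter together in compound 4. A cyclohexylamino group would keep the hydrogen without the aromatic ring, and a methyl(phenyl)amino group would keep the ring without the hydrogen.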